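Removing the vinyl double bond from the sulfonyl of compound 3

The source may hold more compounds than are shown below. What is called first, only, known or untested is meant among the compounds shown, and "the series" means these compounds.

Of the compounds shown here, three sharing one core have been measured in a functional assay on MDA-MB-231 cells (Homo sapiens) for antiproliferative activity, read by MTT assay, with a stated time of 48 h; on this read-out lower numbers stand for stronger inhibition and higher numbers for weaker inhibition. Compound 1 `C=CS(=O)(=O)N1CCN(c2ncnc3sc(-c4ccccc4)cc23)CC1` gives 54200 nM. Compound 2 `C=CS(=O)(=O)N1CCN(c2ncnc3sc(-c4ccc(C(F)(F)F)cc4)cc23)CC1` gives 6410 nM, and compound 3 `C=CS(=O)(=O)N1CCN(c2ncnc3sc(-c4ccc(N5CCN(C)CC5)cc4)cc23)CC1` gives 7550 nM. Compound 3 stands second highest of the three, near compound 2 and far from compound 1: the steps of a 7.2-fold lower number from compound 1 to compound 3 (0.86 log units; beyond the scatter) and a 1.2-fold higher number from compound 2 to compound 3 (0.07 log units; within the scatter) place it there.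

Compound 4 `CCS(=O)(=O)N1CCN(c2ncnc3sc(-c4ccc(N5CCN(C)CC5)cc4)cc23)CC1` differs from compound 3 at the sulfonyl sulfur: ethyl in place of vinyl on a sulfonyl sulfur. Going by the values given here, every measured step so far changes the substituent on the aromatic carbon, while the vinylsulfonyl group is kept in all three compounds; no measured step touches the sulfonyl position, so none bears directly on this change. Among the compounds with values here, the only anchor is compound 3 itself, and the change removes a double bond outside aromatic rings that all three measured compounds carry. For compound 4 in this assay the expected step is a 3.3-fold higher number from compound 3 to compound 4 (0.52 log units; beyond the scatter), toward a higher number, with wide uncertainty. Compound 4 is therefore estimated at 25000 nM, in the range 5000 nM to 100000 nM.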

Compound 4, half-maximal inhibitory concentration: 7330 nM
Estimate against measurement, compound 4: 3.4-fold (0.53 log units) above, within the range that was stated.
By their numbers in this assay, from the lowest: compounds 2, 4 and 3 (each within the scatter of the next); then compound 1.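

In this assay, the step at the sulfonyl position (a 1.0-fold lower number from compound 3 to compound 4 (0.01 log units; within the scatter)) lies within the scatter, so compound 3 and compound 4 cannot be told apart. This is the only step shown at this position, and it indicates that, with 4-methylpiperazin-1-yl on the aromatic carbon, the double bond outside aromatic rings carried by the three earlier compounds is not needed for this level of antiproliferative activity. No measured evidence is available to explain this result.

The compounds shown leave open whether ethyl in place of vinyl would read the same way with trifluoromethyl as in compound 2, or with hydrogen as in compound 1. They also leave open how a longer chain, a phenyl ring or an amine on the sulfonyl sulfur would read.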